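This account rests on a few compounds, and the source may have more. Where it says the series, first, only, none or still open, it means among the compounds named here.

Values in an ADME assay on MRC5 cells (Homo sapiens) for inhibition, with a stated time of 72 h (a higher number here means that more compound is needed for the effect, a lower number that less compound is needed), for the measured compounds:

compound 1 `CO[C@H]1CC[C@H](NC(=O)c2n[nH]cc2NC(=O)c2ccccc2C(F)(F)F)CC1` — 3300 nM
compound 2 `CO[C@H]1CC[C@H](NC(=O)c2n[nH]cc2NC(=O)c2cc3ccccn3n2)CC1` — 1000 nM
compound 3 `COCCNC(=O)c1n[nH]cc1NC(=O)c1c(OC)cccc1OC` — > 50000 nM

Compound 1 and compound 2 give numbers in this assay, and the two values differ. For compound 3 the entry > 50000 nM is a limit of this assay and not a measured number; the evidence for it is the limit of > 50000 nM in this assay, at which 1 of the 3 values shown sits. Of the three values shown, compound 3 therefore stands apart: it marks the edge of what this assay reports, with no number to place it against the others.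

Compound 4 `COc1cccc(OC)c1C(=O)Nc1c[nH]nc1C(=O)NCCCOC(C)C` is the next compound in the series and has not yet been measured in this assay. Its difference from compound 3 is isopropoxymethyl in place of methoxy on a saturated chain carbon, two bonds along the chain from an amide-type nitrogen. For the measured compounds named here, no step between measured compounds is available to calibrate this change, and the starting point is a limit rather than a value. The expectation is that the change from compound 3 to compound 4 gives no step beyond the scatter, a step that the limit leaves unreadable from compound 3 to compound 4, and that compound 4 is again reported at or near the limit. The estimate for compound 4 is 60000 nM, with an expected range of 20000 nM to 200000 nM.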

Compound 4, half-maximal effective concentration: > 50000 nM
Compound 4: no number, only a limit; the forecaster's own chance of this, stated with the estimate: 75%; the middle value does not contradict the limit.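

In this assay, compound 3 and compound 4 are both reported only as limits, so no step can be read between them: the limit of > 50000 nM in this assay, at which 2 of the 4 values shown sit.

The compounds shown leave open whether isopropoxymethyl in place of methoxy at this chain position changes the half-maximal effective concentration at all.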